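Oxanyl for difluorocyclohexyl at the benzylic amine

A few compounds are considered here, and "the series" means these few. Any claim that something is new, unique, unknown or untested is made for them only; others in the source may bear on it.

Three members of the series carry numbers in a functional assay on cells for antagonist activity at C-X-C chemokine receptor type 4 (Homo sapiens), read by fluorescence and calcium flux, with stated times of 25 min and 90 s; a lower number here means a stronger inhibitor, a higher number a weaker inhibitor. Compound 1 `CC1(C)CCC(NCCCCN(C[C@H]2Cc3ccccc3CN2)[C@H]2CCCc3cccnc32)CC1` gives 77.6 nM. Compound 2 `NCc1ccccc1CN(C[C@H]1Cc2ccccc2CN1)[C@H]1CCCc2cccnc21` gives 50.8 nM. Compound 3 `FC1(F)CCC(NCc2ccc(CN(C[C@H]3Cc4ccccc4CN3)[C@H]3CCCc4cccnc43)cc2)CC1` gives 143 nM, the highest of the three numbers; its gap to compound 1 lies within the scatter, whereas compound 2 sits beyond the scatter with the lower number. Within the data shown here, no two measured compounds differ in only one place, so no single step is known in this assay. Compound 4 `c1ccc2c(c1)CN[C@@H](CN(Cc1ccc(CNC3CCOCC3)cc1)[C@H]1CCCc3cccnc31)C2` differs from compound 3 by oxan-4-yl in place of 4,4-difluorocyclohexyl on an amine nitrogen. With nothing measured to rest on, no shift beyond the scatter is expected in this assay, in either direction. The estimated step of a 1.0-fold higher number from compound 3 to compound 4 (0.02 log units; within the scatter) stays within the scatter. Compound 4 is expected to give 150 nM, in the range 60 nM to 400 nM.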

Compound 4, half-maximal inhibitory concentration: 90.3 nM
Estimate against measurement, compound 4: 1.7-fold (0.22 log units) above; the range from low to high includes it.
By their numbers in this assay, from the lowest: compounds 2, 1, 4 and 3 (each within the scatter of the next, the first and the last beyond it).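

Among these compounds, the step of a 1.6-fold lower number from compound 3 to compound 4 (0.20 log units; within the scatter) in this assay is the first single-place comparison, and it stays within the scatter. On this amine nitrogen, oxan-4-yl can therefore stand in place of 4,4-difluorocyclohexyl, with its one ring oxygen replacing the two fluorines, without a readable shift. No measured property bears on the size of this step.

Still open, on these data alone, is whether a piperidin-4-yl or cyclopropyl group on this nitrogen would move the number beyond the scatter. As far as these compounds go, whether the same exchange behaves alike on another linker also remains open.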